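This account rests on a few compounds, and the source may have more. Where it says the series, first, only, none or still open, it means among the compounds named here.

Measured compounds:
- Compound 1 `O=C1CSC(N2N=C(c3ccc(Br)cc3)CC2c2ccc3ccccc3c2)=N1`: 18200 nM
- Compound 2 `Brc1ccc(C2=NN(C3=NC(c4ccccc4)CS3)C(c3ccc4ccccc4c3)C2)cc1`: 20300 nM

Both compounds were tested in a functional assay on HepG2 cells (Homo sapiens) for inhibition, read by CCK-8 assay, with a stated time of 48 h; a higher number here means a weaker inhibitor, a lower number a stronger inhibitor. Going by the values given here, compound 1, at 18200 nM, stands level with compound 2, the only other measured compound, within the scatter. The next compound, compound 3 `Cc1ccc(C2=NN(C3=NC(=O)CS3)C(c3ccc4ccccc4c3)C2)cc1C`, keeps the core of compound 1 and changes one aryl group: 3,4-dimethylphenyl in place of 4-bromophenyl on a carbon with a double bond to nitrogen. In short, 3,4-dimethylphenyl stands in place of 4-bromophenyl on a carbon with a double bond to nitrogen. Among the compounds with values here, the only measured step, a 1.1-fold higher number from compound 1 to compound 2 (0.05 log units; within the scatter), lies at another place, on an amine nitrogen in a ring, and gives no direct reading of this change. Within the data shown here, no measured compound varies this aryl group, so no step beyond the scatter can be predicted, and the value of compound 1, 18200 nM, serves as the anchor. The expected change is a 1.0-fold lower number from compound 1 to compound 3 (0.00 log units; within the scatter). For compound 3 the estimated value is 18000 nM, with an expected range from 8000 nM to 40000 nM.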

Compound 3, half-maximal inhibitory concentration: 8490 nM
Compound 3: middle estimate off by 2.1-fold (0.33 log units), on the high side; the range from low to high includes it.
By their numbers in this assay, from the lowest: compound 3; then compounds 1 and 2 (each within the scatter of the next).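

With 3,4-dimethylphenyl in place of 4-bromophenyl on a carbon with a double bond to nitrogen, this assay shows a 2.1-fold lower number from compound 1 to compound 3 (0.33 log units; beyond the scatter) as a modest but real step beyond the scatter. The earlier pair differed only in the group on the ring nitrogen and stayed within the scatter, so this aryl group is the first place among the compounds shown where a single change moves the number. No measurement available here explains the step, and the change replaces the bromine and adds two methyl groups in one move, so no part of it can be credited to either alteration.

The compounds shown leave open how an unsubstituted phenyl, a phenyl with one methyl group, or a phenyl with a methoxy group or an amine would compare at this place. They also leave open whether 3,4-dimethylphenyl would give a similar step on the core of compound 2.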